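Cyano for bromo on the aryl ring of compound 2

This account rests on a few compounds, and the source may have more. Where it says the series, first, only, none or still open, it means among the compounds named here.

Compound 1 `COC(=O)C1=C(C)N=C(C)/C(=C(\O)OC)C1c1ccccc1N` and compound 2 `COC(=O)C1=C(C)N=C(C)/C(=C(\O)OC)C1c1cccc(Br)c1` share one core and differ only in the aryl group on a saturated ring carbon. In a functional assay (muscle tissue) with Cavia porcellus as the target (a higher number here means that more compound is needed for the effect, a lower number that less compound is needed), compound 1 gives 39800 nM, while compound 2 gives 1.29 nM; the step is a 31000-fold lower number from compound 1 to compound 2 (4.49 log units; beyond the scatter). Compound 2 thus stands lowest of the two numbers measured, with compound 1 the nearest neighbour far above it. Compound 3 `COC(=O)C1=C(C)N=C(C)/C(=C(\O)OC)C1c1cccc(C#N)c1` keeps the core and the phenyl ring of compound 2 and differs by cyano in place of bromo on an aromatic carbon. Among the compounds with values here, no measured step concerns a swap on the aryl ring itself; the single step measured shows only that the aryl group can move the number a long way. A 3-cyanophenyl is expected to keep compound 3 close to compound 2, with at most a modest upward shift, so the expected step is a 2.3-fold higher number from compound 2 to compound 3 (0.37 log units; beyond the scatter). Compound 3 is therefore estimated at 3 nM, within 0.8 nM to 12 nM.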

Compound 3, half-maximal effective concentration: 34.7 nM
Beside the measured number, compound 3's estimate is 12-fold (1.06 log units) below it; measured number outside the range, above it.
By their numbers in this assay, from the lowest: compound 2; then compound 3; then compound 1.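

The change on the aryl ring is not a neutral one: in this assay, cyano in place of bromo, on an aromatic carbon meta to a large group, gives a 27-fold higher number from compound 2 to compound 3 (1.43 log units; beyond the scatter) and is rated large. Within the data shown here, the earlier step showed only that the whole aryl group can move the number, whereas this one shows that a single substituent at this place can do so too, although the 3-cyanophenyl still keeps much of the distance from the 2-aminophenyl, with a 1100-fold lower number from compound 1 to compound 3 (3.06 log units; beyond the scatter) in the same assay. No evidence at hand bears on what lies behind the gap between bromo and cyano.

Open, as far as these compounds go, is where chloro, methoxy or an amine at this same place would fall relative to bromo and cyano. Also open, from the compounds shown here alone, is how much of the distance to compound 1 belongs to the group itself and how much to its place on the ring.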